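A fluoro swap on compound 2

The compounds below may be only part of what the source reports. "The series", "measured", "known", "first", "only" and "open" are said of these compounds alone.

Measured in a functional assay on MCF7 cells (Homo sapiens) for inhibition, read by MTT assay, with a stated time of 72 h (a higher number here means a weaker inhibitor, a lower number a stronger inhibitor), so far:
compound 1 `COc1cc2c(Oc3ccc(NC(=O)c4nn(-c5ccccc5C)cc(C)c4=O)cc3)ccnc2cc1OCCCC(=O)NO` gives 1600 nM
compound 2 `COc1cc2c(Oc3ccc(NC(=O)c4nn(-c5ccccc5C)cc(C)c4=O)cc3)ccnc2cc1OCCCCCCC(=O)NO` gives 1830 nM
compound 3 `COc1cc2c(Oc3ccc(NC(=O)c4nn(-c5ccc(C)cc5C)cc(C)c4=O)cc3)ccnc2cc1OCCCCCCC(=O)NO` gives 2430 nM

Compound 2 cannot be told apart from the other two compounds on these numbers. The data show a 1.1-fold higher number from compound 1 to compound 2 (0.06 log units; within the scatter) and a 1.3-fold higher number from compound 2 to compound 3 (0.12 log units; within the scatter) and neither step leaves the normal spread of repeated measurements.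

Compound 4 `COc1cc2c(Oc3ccc(NC(=O)c4nn(-c5ccccc5C)cc(C)c4=O)c(F)c3)ccnc2cc1OCCCCCCC(=O)NO` is compound 2 with a single change: fluoro in place of hydrogen on an aromatic carbon which in words is fluoro in place of hydrogen on an aromatic carbon. Among the measured compounds shown here, no measured pair shows this swap, so there is no direct guide. The step to compound 3 is the nearest one, as it too places a small group on an aromatic carbon, though that group is methyl. It gave a 1.3-fold higher number from compound 2 to compound 3 (0.12 log units; within the scatter) and so no step beyond the scatter is expected in this assay for compound 4. The step to compound 2 from compound 1 concerns the chain and bears on this change only weakly. No direction can be argued from three such close numbers. The estimate therefore means a 1.0-fold higher number from compound 2 to compound 4 (0.02 log units; within the scatter) and that expected step is too small to read as a change. The estimated value for compound 4 is 1900 nM within an expected range of 950 nM to 3600 nM at this stage.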

Compound 4, half-maximal inhibitory concentration: 2690 nM
For compound 4 the middle estimate is 1.4-fold (0.15 log units) below the measured one; the range from low to high includes it.
By their numbers in this assay, from the lowest: compounds 1, 2, 3 and 4 (each within the scatter of the next).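

In this assay, fluoro in place of hydrogen on an aromatic carbon, ortho to a large group and meta to a large group, gives a 1.5-fold higher number from compound 2 to compound 4 (0.17 log units; within the scatter), so this position accepts the added fluorine atom without a change that can be read in this assay. The earlier steps covered only the length of the chain and a methyl on a different aromatic carbon, so this is the only step shown that tests this position, and it places compound 4 within the scatter of compound 2. No measurement is available here that speaks to what lies behind this small step.

Going by these compounds, one small atom at one position is a narrow test, so it remains open whether chloro, methoxy or an amine in the same place would also leave the number within the scatter. It is equally open whether fluoro would behave the same way on the shorter chain of compound 1 or alongside the extra methyl of compound 3, since neither of those fluoro compounds is among those shown.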